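The compounds below may be only part of what the source reports. "The series", "measured", "known", "first", "only" and "open" are said of these compounds alone.

Going by the values given here, compound 2 `C#CCSc1nc(Nc2ccc(Cl)cc2)c2ccncc2n1` is the only compound with a number in a functional assay on PC-3 cells (Homo sapiens) for inhibition, read by MTT assay, with a stated time of 72 h (a lower number here means a stronger inhibitor, a higher number a weaker inhibitor), where compound 2 gives 19000 nM. Compound 1 `C#CCSc1nc(Nc2ccccc2)c2ccncc2n1` gives only a limit of this assay, > 80000 nM. Among the compounds with values here, the single measured step, an at least 4.2-fold lower number from compound 1 to compound 2 (0.62 log units; beyond the scatter), puts chloro in place of hydrogen and starts from the limit of > 80000 nM in this assay, at which 1 of the 2 values shown sits. Compound 3 `C#CCSc1nc(Nc2ccc([N+](=O)[O-])cc2)c2ccncc2n1` differs from compound 2 by nitro in place of chloro on an aromatic carbon. Within the data shown here, no measured step exchanges one group for another; the chloro step bears only loosely on this change. A step within the scatter is expected, namely a 1.3-fold lower number from compound 2 to compound 3 (0.10 log units; within the scatter). Compound 3 is therefore estimated at 15000 nM, between 5000 nM and 60000 nM.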

Compound 3, half-maximal inhibitory concentration: > 80000 nM
Compound 3 was reported as a limit; the forecaster's own chance of this, stated with the estimate: 15%; middle value at least 5.3-fold (0.72 log units) away from the limit.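

Putting nitro in place of chloro gives an at least 4.2-fold higher number from compound 2 to compound 3 (0.62 log units; beyond the scatter), so in this assay nitro does not share the gain seen with chloro at this position, para to a large group. The step from compound 1 to compound 3 cannot be read, as both values are limits. Of the three groups at this position, hydrogen, chloro and nitro, only chloro gives a real number, and the other two stop at the same limit: the limit of > 80000 nM in this assay, at which 2 of the 3 values shown sit.

Going by these compounds, whether fluoro, bromo, methoxy or an amine at this position would also give a number stays open. With a single real number, no ranking among groups can be drawn.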